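The source may hold more compounds than are shown below. What is called first, only, known or untested is meant among the compounds shown, and "the series" means these compounds.

Measured compounds:
compound 1, `ClCc1ccc(Cn2cnc3c(Cl)ncnc32)cc1`, in a functional assay on CCRF-CEM cells (Homo sapiens) for cytotoxicity, read by sulforhodamine B assay, with a stated time of 48 h; on this read-out lower numbers stand for higher toxicity in this test and higher numbers for lower toxicity in this test: > 100000 nM
compound 2, `ClCc1ccccc1Cn1cnc2ncnc(Cl)c21`: 8700 nM
compound 3, `ClCc1ccc(Cn2cnc3c(Cl)nc(Cl)nc32)cc1`: 14100 nM.

Compound 1 gives in this assay the value > 100000 nM, which is a limit of the assay and not a number. Compound 3 differs from compound 1 by chloro in place of hydrogen on an aromatic carbon, and this change gives an at least 7.0-fold lower number from compound 1 to compound 3 (0.85 log units; beyond the scatter). The size of this step can be stated only as a bound because of the limit of > 100000 nM in this assay, at which 1 of the 3 values shown sits. Compound 2, with 8700 nM, has the same atoms as compound 1 joined differently; the difference between the two cores is not broken down here. Compound 2 and compound 3 give numbers that lie within the usual scatter of each other, so no order between them is claimed.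

Compound 4, `ClCc1ccccc1Cn1cnc2nc(Cl)nc(Cl)c21`, has not yet been measured in this assay. It differs from compound 2 by chloro in place of hydrogen on an aromatic carbon, the same change that leads from compound 1 to compound 3. Since compound 1 gives only a limit, the earlier step is known only as a bound, and the expectation for compound 4 rests on that bound together with the number of compound 2. For compound 4 a step of a 3.5-fold lower number from compound 2 to compound 4 (0.54 log units; beyond the scatter) is expected from compound 2. Compound 4 is therefore estimated at 2500 nM in this assay, with a range from 800 nM to 8000 nM.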

Compound 4, concentration lethal to 50% of the cells: 930 nM
For compound 4 the middle estimate is 2.7-fold (0.43 log units) above the measured one, and the stated range covers the measured number.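

In this assay, chloro in place of hydrogen on an aromatic carbon, here the carbon between two ring nitrogen atoms, gives a 9.4-fold lower number from compound 2 to compound 4 (0.97 log units; beyond the scatter), and the same change lowers the number on both cores: the same change on two cores in this assay, an at least 7.0-fold lower number (0.85 log units; beyond the scatter) from compound 1 to compound 3 and a 9.4-fold lower number (0.97 log units; beyond the scatter) from compound 2 to compound 4; the limit leaves it open whether they differ. The direction of the step therefore carries over from the core of compound 1 to the core of compound 2, though this rests on only these two pairs and says nothing about any other core. Compound 1 gives a limit of the assay and not a number, so the data do not show whether the step has the same size on the two cores: the limit of > 100000 nM in this assay, at which 1 of the 4 values shown sits.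

The compounds shown carry only hydrogen or chloro on this carbon, so it remains open how an amine, a methoxy group or a longer chain at the same place would compare in this assay. All four compounds also keep their chloromethyl group, which leaves open how the numbers would respond if a hydroxymethyl or plain methyl group stood in its place, and whether the chloro step would then still run the same way.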